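The source may hold more compounds than are shown below. What is called first, only, known or untested is meant among the compounds shown, and "the series" means these compounds.

Measured in a functional assay on MCF7 cells (Homo sapiens) for antiproliferative activity; a higher number here means a weaker inhibitor, a lower number a stronger inhibitor:

- Compound 1 `CC(C)=CCc1cc(C(=O)Nc2cc3ccc(OCCCNC(C)C)c(C)c3oc2=O)ccc1O`: 740 nM
- Compound 2 `CC(C)=CCc1cc(C(=O)Nc2cc3ccc(OCCCNCCO)c(C)c3oc2=O)ccc1O`: 1560 nM
- Compound 3 `CC(C)=CCc1cc(C(=O)Nc2cc3ccc(OCCCNc4ccccc4)c(C)c3oc2=O)ccc1O`: > 50000 nM, a limit and not a number

Going by these compounds, compound 3 is the weakest of the three, and its entry in this assay is only a limit, so its true value is unknown. The steps that bear most closely on it both put phenyl on the amine nitrogen. They are large: an at least 67-fold higher number from compound 1 to compound 3 (1.82 log units; beyond the scatter) and an at least 32-fold higher number from compound 2 to compound 3 (1.50 log units; beyond the scatter). By comparison, a 2.1-fold higher number from compound 1 to compound 2 (0.32 log units; beyond the scatter) is modest.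

Compound 4 `CC(C)=CCc1cc(C(=O)Nc2cc3ccc(OCCCN(C)c4ccccc4)c(C)c3oc2=O)ccc1O` keeps that phenyl and makes one change, methyl in place of hydrogen on a nitrogen on an aromatic ring. Going by the values given here, no measured step makes this exact swap, so the evidence is indirect. Compound 4 is expected to stay weak, like compound 3 at > 50000 nM, and it may again reach only a limit. Any real change could show only as a lower number. The expected result is an at least 1.6-fold lower number from compound 3 to compound 4 (0.22 log units; that floor lies within the scatter). For compound 4, the estimate is 30000 nM, with an expected range of 5000 nM to 50000 nM.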

Compound 4, half-maximal inhibitory concentration: > 50000 nM
Compound 4: a limit, no number (the forecaster's own chance of this, stated with the estimate: 55%); at least 1.6-fold (0.22 log units) between middle value and limit.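

In this assay compound 4 gives > 50000 nM, which is a limit of the assay and not a number. With phenyl on the amine nitrogen, replacing the remaining hydrogen with methyl therefore does not produce a measurable value, and the large gap to the compounds without phenyl remains: an at least 67-fold higher number from compound 1 to compound 4 (1.82 log units; beyond the scatter) and an at least 32-fold higher number from compound 2 to compound 4 (1.50 log units; beyond the scatter). The size of the methyl step itself cannot be read, because compound 3 and compound 4 both stop at the same limit: the limit of > 50000 nM in this assay, at which 2 of the 4 values shown sit.

The compounds shown leave open whether the loss of activity is specific to phenyl, or whether a benzyl group or a cyclohexyl ring on the same nitrogen would also leave a compound this weak. They also leave open what methyl would do on the nitrogen of the isopropylamino group in compound 1, where a change in either direction could be measured.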